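From pyridin-4-yl to 2-chloropyridin-3-yl in compound 3

This account rests on a few compounds, and the source may have more. Where it says the series, first, only, none or still open, it means among the compounds named here.

Measured so far in an ADME assay on A549 cells (Homo sapiens) for cytotoxicity, read by resazurin assay, with a stated time of 48 h; on this read-out lower numbers stand for higher toxicity in this test and higher numbers for lower toxicity in this test:
compound 1 `CC(C)CNc1ccc(NC(=O)c2cc(Cl)ccc2O)c(Cl)c1` gives 60000 nM
compound 2 `O=C(Nc1ccc(NCc2ccc(O)cc2)cc1Cl)c1cc(Cl)ccc1O` gives 116000 nM
compound 3 `O=C(Nc1ccc(NCc2ccncc2)cc1Cl)c1cc(Cl)ccc1O` gives 65300 nM

Compound 3 cannot be separated from the other two on these numbers: the steps read a 1.1-fold higher number from compound 1 to compound 3 (0.04 log units; within the scatter) and a 1.8-fold lower number from compound 2 to compound 3 (0.25 log units; within the scatter) and both stay inside normal repeat variation. Compound 4 `O=C(Nc1ccc(NCc2cccnc2Cl)cc1Cl)c1cc(Cl)ccc1O` keeps the shared core and makes one change, counted as 2-chloropyridin-3-yl in place of pyridin-4-yl on a saturated chain carbon bound to a nitrogen on an aromatic ring in all. In words, this is 2-chloropyridin-3-yl in place of pyridin-4-yl on a saturated chain carbon bound to a nitrogen on an aromatic ring.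

Three swaps at this same place have been measured, a 1.9-fold higher number from compound 1 to compound 2 (0.29 log units; within the scatter) along with the two above, and none left the scatter, although isopropyl, 4-hydroxyphenyl and pyridin-4-yl are very different groups. Among the compounds with values here, no measured compound carries 2-chloropyridin-3-yl, so the new group itself remains untested. No clear change is therefore expected in this assay, and the estimated step is a 1.1-fold lower number from compound 3 to compound 4 (0.04 log units; within the scatter) with no firm direction. For compound 4 the estimated value is 60000 nM with an expected range from 28000 nM to 125000 nM overall.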

Compound 4, half-maximal cytotoxic concentration: 101000 nM
The estimate for compound 4 lay 1.7-fold (0.23 log units) below the measured number, and the stated range covers the measured number.
By their numbers in this assay, from the lowest: compounds 1, 3, 4 and 2 (each within the scatter of the next).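

In this assay, a fourth group at this place, on a saturated chain carbon bound to a nitrogen on an aromatic ring, still stays inside the scatter against all three earlier groups (a 1.5-fold higher number from compound 3 to compound 4 (0.19 log units; within the scatter)), (a 1.1-fold lower number from compound 2 to compound 4 (0.06 log units; within the scatter)), (a 1.7-fold higher number from compound 1 to compound 4 (0.23 log units; within the scatter)). This extends the flat picture to a group that carries a chlorine, which none of the earlier groups at this place did, so all six steps among compounds 1, 2, 3 and 4 now lie within the scatter. No supporting measurement bears on this result.

On these data alone, it remains open whether any group on this carbon can move the number beyond the scatter, such as a carboxylic acid or a longer chain. A plain pyridin-3-yl group would also be needed to tell the effect of the chlorine apart from that of the different ring attachment.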